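This account rests on a few compounds, and the source may have more. Where it says the series, first, only, none or still open, it means among the compounds named here.

Compound 3 `Cc1ccc(Nc2nc(C)c(C(=O)/C=C/c3ccccc3Cl)s2)cc1` stands only at a limit: in a functional assay on Bel-7402 cells (Homo sapiens) for cytotoxicity, read by MTT assay (on this read-out higher numbers stand for weaker inhibition and lower numbers for stronger inhibition), compound 3 gives > 25000 nM. Compound 1 `Cc1ccccc1Nc1nc(C)c(C(=O)/C=C/c2ccccc2Cl)s1` likewise reaches only the limit, giving > 25000 nM in this assay. Compound 2 `COc1cccc(/C=C/C(=O)c2sc(Nc3cccc(Cl)c3)nc2C)c1` is also reported only as the limit > 25000 nM in this assay. The step that the two limits leave unreadable from compound 1 to compound 3 therefore has no readable size, and the limit of > 25000 nM in this assay, at which 3 of the 3 values shown sit, is all the measured values show. Compound 4 `COc1cccc(/C=C/C(=O)c2sc(Nc3ccc(C)cc3)nc2C)c1` differs from compound 3 by 3-methoxyphenyl in place of 2-chlorophenyl on a double-bonded chain carbon bound to a double-bonded chain carbon. Going by the values given here, no measured step isolates this change; compound 2 carries the same 3-methoxyphenyl and sits at the limit. The step that the limit leaves unreadable from compound 3 to compound 4 is thus expected to be flat, nothing beyond the scatter. Compound 4 is estimated to give about 40000 nM, in the range 20000 nM to 100000 nM, most likely reported again only as a limit.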

Compound 4, half-maximal inhibitory concentration: > 25000 nM
Compound 4 ended at the assay's limit (the forecaster's own chance of this, stated with the estimate: 85%); the middle value is on the limit's open side.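

The steps from compound 3 and compound 2 to compound 4 cannot be read, since compound 4 also stands only at a limit: the limit of > 25000 nM in this assay, at which 4 of the 4 values shown sit.

The compounds shown leave open which change to the shared core, if any, would give a readable value in this assay.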